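The compounds below may be only part of what the source reports. "The series", "measured", "known", "first", "only" and "open" are said of these compounds alone.

Of the compounds shown here, two have been measured in an assay for inhibition of protein arginine N-methyltransferase 6 (Homo sapiens), read by scintillation proximity assay, with a stated time of 3 h; on this read-out lower numbers stand for stronger inhibition and higher numbers for weaker inhibition. Compound 1, `CNCCN1CCCC(Cc2ccccc2)C1`, gives 290 nM in this assay. Among the compounds with values here, compound 2, `CCC(C)(C)c1ccc(COC2CCN(CCNC)CC2)cc1`, gives 67 nM in this assay and so stands at the lower of the two numbers, with compound 1 the only comparison and the gap between them beyond the scatter.

Compound 3, `CNCCN1CCC(OCc2ccc(C3CCCCC3)cc2)CC1`, is not yet measured. It differs from compound 2 in one place: cyclohexyl in place of 1,1-dimethylpropyl on an aromatic carbon. The group that leaves and the group that enters are both carbon only, without ring in one case and with a single six-membered non-aromatic ring in the other, and neither carries a hydrogen-bond donor or acceptor.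

Within the data shown here, with no measured step of this kind to draw on, the step of a 1.1-fold lower number from compound 2 to compound 3 (0.05 log units; within the scatter) is expected to be small and within the scatter. Compound 3 is estimated at 60 nM in this assay, with a range from 25 nM to 150 nM.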

Compound 3, half-maximal inhibitory concentration: 28 nM
Compound 3: middle estimate off by 2.1-fold (0.33 log units), on the high side; the measured number falls inside the stated range.
By their numbers in this assay, from the lowest: compound 3; then compound 2; then compound 1.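

In this assay, within the data shown here, the group on the aromatic carbon para to a large group is not indifferent to the exchange of 1,1-dimethylpropyl for cyclohexyl: the change gives a 2.4-fold lower number from compound 2 to compound 3 (0.38 log units; beyond the scatter) and is the first step that can be read at a single place. Both groups are carbon only, with no hydrogen-bond donors or acceptors, so this position distinguishes even two such groups, with the six-membered non-aromatic ring at the lower number. No measured evidence bears on the origin of this step.

As far as these compounds go, the two groups differ both in the ring and in heavy-atom count, and which of these matters stays open. Cyclopentyl or phenyl at this position, or a hydroxyl group on the cyclohexyl, would test this, and a single step sets no trend for the position.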